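Amide substituent variation on a naphthyl thiazolidinedione series

This account rests on a few compounds, and the source may have more. Where it says the series, first, only, none or still open, it means among the compounds named here.

Compound 1 `Cc1ccc(NC(=O)COc2ccc3cc(/C=C4/SC(=O)NC4=O)ccc3c2)cc1`: 9000 nM in an assay on isolated protein for inhibition of histone deacetylase 8 (Homo sapiens), with a stated time of 1 h; on this read-out lower numbers stand for stronger inhibition and higher numbers for weaker inhibition
Compound 2 `O=C(COc1ccc2cc(/C=C3/SC(=O)NC3=O)ccc2c1)Nc1ccccn1`: > 50000 nM, a limit
Compound 3 `Cc1cc(NC(=O)COc2ccc3cc(/C=C4/SC(=O)NC4=O)ccc3c2)no1`: > 50000 nM, a limit

Within the data shown here, compound 1 holds the only numerical value; the two other entries are limits, as the limit of > 50000 nM in this assay, at which 2 of the 3 values shown sit, records. From compound 1 the swap to pyridin-2-yl gave an at least 5.5-fold higher number from compound 1 to compound 2 (0.74 log units; beyond the scatter), and the swap to 5-methyl-1,2-oxazol-3-yl gave an at least 5.5-fold higher number from compound 1 to compound 3 (0.74 log units; beyond the scatter). Between compound 2 and compound 3 both values are limits, so nothing can be read. Compound 4 `O=C(COc1ccc2cc(/C=C3/SC(=O)NC3=O)ccc2c1)Nc1cccc(Cl)c1` differs from compound 1 by 3-chlorophenyl in place of 4-methylphenyl on an amide-type nitrogen. Unlike both measured steps, the group that enters is again a six-membered aromatic ring of carbon only, so a smaller step than either is expected, or none beyond the scatter. The step from compound 1 to compound 4 is estimated at a 1.3-fold higher number from compound 1 to compound 4 (0.12 log units; within the scatter). Compound 4 is therefore expected at 12000 nM, between 4000 nM and 40000 nM.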

Compound 4, half-maximal inhibitory concentration: > 50000 nM
Compound 4 gave a limit, no number (the forecaster's own chance of this, stated with the estimate: 20%); middle value at least 4.1-fold (0.61 log units) away from the limit.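

Replacing 4-methylphenyl with 3-chlorophenyl on the amide-type nitrogen gave an at least 5.5-fold higher number from compound 1 to compound 4 (0.74 log units; beyond the scatter), so keeping a six-membered aromatic ring of carbon only, with the same heavy-atom count, does not preserve the reading of compound 1. The value of compound 4 is a limit, not a number, and the steps among compound 2, compound 3 and compound 4 cannot be read. Only one value in the series is a number: the limit of > 50000 nM in this assay, at which 3 of the 4 values shown sit.

As far as these compounds go, whether the change follows from the chlorine or from where the substituent sits remains open. The 3-methylphenyl and 4-chlorophenyl amides would separate the two.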